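Amide nitrogen swap on a catechol diether PDE4 scaffold

This account rests on a few compounds, and the source may have more. Where it says the series, first, only, none or still open, it means among the compounds named here.

Measured compounds:
compound 1, `COc1ccc(C(=O)Nc2ccccc2Cl)cc1OC1CCCC1`: 190 nM
compound 2, `COc1ccc(C(=O)Nc2c(Br)cncc2Br)cc1OC1CCCC1`: 7 nM

Both compounds were tested in an assay on isolated protein for inhibition of phosphodiesterase 4A (Sus scrofa); on this read-out lower numbers stand for stronger inhibition and higher numbers for weaker inhibition. Compound 1 gives 190 nM and compound 2 gives 7 nM, so compound 2 has the lower of the two numbers; the single step shown, a 27-fold lower number from compound 1 to compound 2 (1.43 log units; beyond the scatter), is large and beyond the scatter. Compound 3, `COc1ccc(C(=O)Nc2c(C)nsc2C#N)cc1OC1CCCC1`, has not yet been measured. It differs from compound 2 in one place: 5-cyano-3-methyl-1,2-thiazol-4-yl in place of 3,5-dibromopyridin-4-yl on an amide-type nitrogen. Among the measured compounds shown here, the one measured step changes the same amide-nitrogen substituent, but it replaced a 2-chlorophenyl by a 3,5-dibromopyridin-4-yl, not the five-membered ring seen here, so it bears on this step only loosely. Nothing shown predicts the direction for a 5-cyano-3-methyl-1,2-thiazol-4-yl. Given how strongly the nitrogen substituent mattered in a 27-fold lower number from compound 1 to compound 2 (1.43 log units; beyond the scatter), a moderate step upward in this assay is expected, a 3.6-fold higher number from compound 2 to compound 3 (0.55 log units; beyond the scatter). Compound 3 is therefore estimated at 25 nM, within 5 nM to 150 nM.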

Compound 3, half-maximal inhibitory concentration: 200 nM
The estimate for compound 3 lay 8.0-fold (0.90 log units) below the measured number, and the stated range ends below it.
By their numbers in this assay, from the lowest: compound 2; then compounds 1 and 3 (each within the scatter of the next).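

In this assay, a 29-fold higher number from compound 2 to compound 3 (1.46 log units; beyond the scatter) shows that the low number of compound 2 does not carry over to every aromatic ring on the amide-type nitrogen, even one of the same heavy-atom count. Alongside this, a 1.1-fold higher number from compound 1 to compound 3 (0.02 log units; within the scatter) places the 5-cyano-3-methyl-1,2-thiazol-4-yl level with the 2-chlorophenyl, so that compound 2 alone stands apart among the three. Nothing measured here accounts for this difference between the substituents.

As far as these compounds go, it remains open whether the bromine atoms or the ring nitrogen of the 3,5-dibromopyridin-4-yl matter more, and whether a 3,5-dichloropyridin-4-yl would keep the number of compound 2. Also open, from the compounds shown here alone, is how the thiazole ring of compound 3 would read with a carboxylic acid in place of its nitrile.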